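Sulfonamide removal on an ethoxy-biphenyl core

The source may report more compounds than this note shows. Statements on the series, on what has been measured and on what is new or still open speak of the compounds shown alone.

Measured so far:
compound 1 `CCNS(=O)(=O)c1cccc(-c2ccc(OCC)cc2)c1`: 200000 nM
compound 2 `CCOc1ccc(-c2cccc(S(=O)(=O)N(C)C)c2)cc1`: 110000 nM

Going by the values given here, in an assay on COS-7 cells for inhibition of patatin-like phospholipase domain-containing protein 2 (Mus musculus) (on this read-out lower numbers stand for stronger inhibition and higher numbers for weaker inhibition), compound 2 gives the lowest of the two numbers, but its only neighbour is compound 1 and the step of a 1.8-fold lower number from compound 1 to compound 2 (0.26 log units; within the scatter) lies within the scatter, so the two compounds stand together as weak inhibitors.

Compound 3 `CCOc1ccc(-c2ccccc2)cc1` is not yet measured. It differs from compound 2 by hydrogen in place of dimethylsulfamoyl on an aromatic carbon. Among the compounds with values here, the single measured step, a 1.8-fold lower number from compound 1 to compound 2 (0.26 log units; within the scatter), changes only the substituents on the sulfonyl nitrogen and bears on the present change only loosely: it shows that exchanging dimethylamino for ethylamino does not move the number beyond the scatter. Within the data shown here, no measured step removes the dimethylsulfamoyl group itself, so the effect of taking it away is not covered by the data. Given that both measured numbers are already very high, the expectation for compound 3 is a number no lower than that of compound 2, possibly higher, and a real chance that this assay reports only a limit. Compound 3 is expected at 300000 nM, range 80000 nM to 1000000 nM. This estimate corresponds to an expected step of a 2.7-fold higher number from compound 2 to compound 3 (0.44 log units; beyond the scatter).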

Compound 3, half-maximal inhibitory concentration: > 200000 nM
Compound 3 ended at the assay's limit (the forecaster's own chance of this, stated with the estimate: 50%); the middle value is on the limit's open side.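

Compound 3 gives > 200000 nM in this assay, which is a limit of the assay and not a number: the limit of > 200000 nM in this assay, at which 1 of the 3 values shown sits.

Going by these compounds alone, for the first time this aromatic carbon carries no sulfonyl-based group, and the result is an at least 1.8-fold higher number from compound 2 to compound 3 (0.25 log units; that floor lies within the scatter); the change can therefore be bounded only from one side, and a much larger loss is as compatible with the data as a loss within the scatter. The step of a number no lower from compound 1 to compound 3 (the limit leaves the size open) cannot be read in size, so the removal of the sulfamoyl groups gives no evidence that either one contributes to inhibition, and none that it does not.

Within the data shown here, the series stays in the weak range throughout, with a 1.8-fold lower number from compound 1 to compound 2 (0.26 log units; within the scatter) as the only step between two measured numbers. As far as these compounds go, whether a carboxylic acid or a primary amine on this aromatic carbon would give a number clearly lower than those of compound 1 and compound 2 remains open. The ethoxy group is constant in all three compounds, so whether a longer chain in its place would change the number is also unresolved.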